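Benzofuran in Place of Carboxyphenyl: Expected Agonist Potency

The compounds below may be only part of what the source reports. "The series", "measured", "known", "first", "only" and "open" are said of these compounds alone.

Measured so far:
compound 1, `Cc1ccccc1-n1nc(C)c2c1NC(=O)[C@H](C)S[C@@H]2c1ccc(-c2cccc(C(=O)O)c2)cc1` — "not active" (no number reported)
compound 2, `CCCc1ccccc1-n1nc(C)c2c1NC(=O)[C@H](C)S[C@@H]2c1ccc(Oc2ccccc2)cc1` — 1100 nM

In an assay on isolated protein for agonist activity at Bile acid receptor (Homo sapiens), read by AlphaScreen, with a stated time of 30 min (on this read-out higher numbers stand for an effect only at larger amounts of compound and lower numbers for an effect already at smaller amounts), compound 1 gives "not active" (no number reported), so no single number places it on the scale; it stands only as a compound without a reported effect. Compound 2, which carries no acid, gives 1100 nM in this assay. Compound 3, `Cc1ccccc1-n1nc(C)c2c1NC(=O)[C@H](C)S[C@@H]2c1ccc(-c2cc3ccccc3o2)cc1`, is not yet measured; it differs from compound 1 by 1-benzofuran-2-yl in place of 3-carboxyphenyl on an aromatic carbon. Within the data shown here, no step between two measured compounds matches this change, so its size can only be guessed. Because compound 2 reaches 1100 nM without an acid, removing the acid from compound 1 is expected to move this assay toward lower numbers, by a step beyond the scatter, though a result without a reported number also remains possible. Compound 3 is expected to give about 1500 nM in this assay, within 300 nM to 8000 nM.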

Compound 3, half-maximal effective concentration: 1500 nM
The estimate for compound 3 equals the measured number at the digits printed, and the stated range covers the measured number.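

Among these compounds, compound 1 gives "not active" (no number reported) and compound 3 gives 1500 nM in the same test, so no step between them can be read. No measurement shown offers an explanation for this result. The compounds shown leave open how large the exchange of 3-carboxyphenyl for 1-benzofuran-2-yl is on this scale.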